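Adding a hydroxy group to the phenyl ring of compound 1

This account rests on a few compounds, and the source may have more. Where it says the series, first, only, none or still open, it means among the compounds named here.

Within the data shown here, compound 1 `CC1(/C=C/c2ccccc2)C=CC(=O)O1` is one of two compounds measured in a functional assay on MCF7 cells (Homo sapiens) for inhibition, read by sulforhodamine B assay, with a stated time of 48 h (on this read-out higher numbers stand for weaker inhibition of growth and lower numbers for stronger inhibition of growth), and compound 1 gives 95300 nM, the highest of the two numbers. Compound 2 `CC1(/C=C/c2ccc(F)cc2)C=CC(=O)O1` gives 38500 nM, with a 2.5-fold lower number from compound 1 to compound 2 (0.39 log units; beyond the scatter). Compound 3 `CC1(/C=C/c2ccccc2O)C=CC(=O)O1` differs from compound 1 by hydroxy in place of hydrogen on an aromatic carbon. Among the measured compounds shown here, the only step that bears on this change is the one from compound 1 to compound 2, which brought a different group to a different place, so it offers only a loose guide. A small lowering of the number is therefore expected, a 1.6-fold lower number from compound 1 to compound 3 (0.20 log units; within the scatter). The estimate for compound 3 in this assay is 60000 nM, within a range from 20000 nM to 180000 nM.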

Compound 3, concentration for total growth inhibition: 46200 nM
Compound 3: middle estimate off by 1.3-fold (0.11 log units), on the high side; measured number inside the range.
By their numbers in this assay, from the lowest: compounds 2 and 3 (each within the scatter of the next); then compound 1.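

In this assay hydroxy in place of hydrogen, ortho to a group of 9 heavy atoms, gives a 2.1-fold lower number from compound 1 to compound 3 (0.31 log units; beyond the scatter) as a modest step beyond the scatter. Until now only fluoro had been seen to lower the number from compound 1, and hydroxy at this place on the aromatic ring does so too. Nothing available here explains why the number falls.

Still open, on these data alone, is whether an amine or a methoxy group at this same place would shift the number, and by how much. As far as these compounds go, whether hydroxy elsewhere on the ring would give a similar step also remains unknown.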